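Swapping a Pyridinylmethyl Thioether Arm for a Small Amide

The source may hold more compounds than are shown below. What is called first, only, known or untested is meant among the compounds shown, and "the series" means these compounds.

Three compounds have been measured so far:
Compound 1, `N#Cc1c(N)nc(SCc2cccnc2)c(C#N)c1-c1ccc(OCC2CC2)cc1`, gives 19% in an assay on CHO cells for displacement of a labelled ligand from adenosine receptor A3 (Homo sapiens), read by scintillation counting, with a stated time of 120 min, tested at 1 uM; a lower number here means less inhibition, a higher number more inhibition at the concentration tested (going by the name of the read-out).
Compound 2, `CCOc1ccc(-c2c(C#N)c(N)nc(SCc3ccn[nH]3)c2C#N)cc1`, gives 18% in this assay.
Compound 3, `N#Cc1c(N)nc2sc(C(N)=O)c(N)c2c1-c1ccc(OCC2CC2)cc1`, gives 13% in this assay.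

Compound 1 shows the highest of the three numbers, but its margin over compound 2 and over compound 3 lies within the usual scatter of repeated measurements, so the three values cannot be placed in any firm order. All three are modest at the concentration tested.

Compound 4, `N#Cc1c(N)nc(SCC(=O)NCO)c(C#N)c1-c1ccc(OCC2CC2)cc1`, has not yet been measured in this assay. It differs from compound 1 in a single place: (hydroxymethyl)carbamoyl in place of pyridin-3-yl on a saturated chain carbon bound to a sulfur. The substituent that leaves carries a six-membered aromatic ring; the one that enters has no ring and brings two hydrogen-bond donors in its place.

Within the data shown here, no measured pair in this set isolates such a change, so the expectation rests on the low level of compound 1 itself. The step from compound 1 to compound 4 is expected to be a number 5 percentage points lower from compound 1 to compound 4 (within the scatter), a small decrease that stays within the scatter. Compound 4 is therefore estimated at 14%, with a range from 3% to 28%.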

Compound 4, a percentage reported as inhibition, at one concentration (the size of the read-out at that concentration, not a potency): 8%
Compound 4: middle estimate off by 6 percentage points, on the high side, and the stated range covers the measured number.
By their numbers in this assay, from the lowest: compounds 4, 3, 2 and 1 (each within the scatter of the next, the first and the last beyond it).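

Among these compounds, compound 4 forms the first pair in this set that differs in one place, and in this assay the change at the saturated chain carbon bound to a sulfur gives a number 11 percentage points lower from compound 1 to compound 4 (beyond the scatter). This shows that the number responds to what this position carries, which the three earlier compounds could not show, as their differences all lay within the scatter and none of them formed such a pair. Pyridin-3-yl, with its six-membered aromatic ring, cannot be exchanged for (hydroxymethyl)carbamoyl without a modest loss of inhibition at the concentration tested, though nothing available explains this step.

This one pair cannot separate the departure of the aromatic ring from the arrival of the amide, and a phenyl group or a plain carbamoyl group at the same place would help to tell those two apart. Also open, on these data alone, is whether a carboxylic acid or a longer chain ending in a hydroxyl group on this arm would stay close to compound 1 or fall close to compound 4.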